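Swapping one five-membered ring for another on the amide side chain

The source may hold more compounds than are shown below. What is called first, only, known or untested is meant among the compounds shown, and "the series" means these compounds.

In an assay on HEK293 cells for agonist activity at transient receptor potential cation channel subfamily M member 8 (Homo sapiens), read by fluorescence and calcium flux, with a stated time of 15 min (on this read-out lower numbers stand for an effect already at smaller amounts and higher numbers for an effect only at larger amounts of compound), compound 1 `Cc1ccc(OCC(=O)N(Cc2cccs2)c2ccn(C)n2)cc1` gives 855 nM, and compound 2 `CCN(Cc1cncs1)C(=O)COc1ccc(C)cc1` gives 1100 nM; the two numbers lie within the usual scatter of each other, so neither can be called the more potent. Compound 3 `CCN(Cc1cccn1C)C(=O)COc1ccc(C)cc1` differs from compound 2 by 1-methyl-1H-pyrrol-2-yl in place of 1,3-thiazol-5-yl on a saturated chain carbon bound to an amide-type nitrogen. Among the measured compounds shown here, with no measured step of this kind available, the expected change from compound 2 to compound 3 is a 1.1-fold higher number from compound 2 to compound 3 (0.04 log units; within the scatter), that is, nothing clearly beyond the scatter in either direction. Compound 3 is therefore estimated to give 1200 nM in this assay, with a plausible range from 400 nM to 4000 nM.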

Compound 3, half-maximal effective concentration: 21300 nM
Compound 3: middle estimate off by 18-fold (1.25 log units), on the low side, and the stated range ends below it.
By their numbers in this assay, from the lowest: compounds 1 and 2 (each within the scatter of the next); then compound 3.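

Which five-membered ring sits on a saturated chain carbon bound to an amide-type nitrogen can matter greatly: in this assay, 1-methyl-1H-pyrrol-2-yl in place of 1,3-thiazol-5-yl gives a 19-fold higher number from compound 2 to compound 3 (1.29 log units; beyond the scatter) and so moves the number well beyond the scatter. Compounds 1 and 2 could not show this, as they differ in more than one place. Nothing shown gives a reason for this step.

Going by these compounds, it remains open whether the step belongs to the methyl or to the ring itself. Plain 1H-pyrrol-2-yl in the same place would separate the two.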